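Fluoro removal on the core of compound 1

The source may hold more compounds than are shown below. What is called first, only, known or untested is meant among the compounds shown, and "the series" means these compounds.

Compound 1 `Fc1ccc2nc(NCCCCN3CCN(c4cccc(Cl)c4Cl)CC3)nc(NCc3ccco3)c2c1` gives 390 nM in a functional assay on HT-29 cells (Homo sapiens) for cytotoxicity, read by MTT assay, with a stated time of 2 days (on this read-out lower numbers stand for stronger inhibition and higher numbers for weaker inhibition), the lowest of the two numbers available. Compound 2 `Cc1cccc(N2CCN(CCCCNc3nc(NCc4ccco4)c4cc(F)ccc4n3)CC2)c1C` gives 1830 nM; the step of a 4.7-fold higher number from compound 1 to compound 2 (0.67 log units; beyond the scatter) concerns a change on the amine nitrogen in a ring and does not bear on the change considered here. Compound 3 `Clc1cccc(N2CCN(CCCCNc3nc(NCc4ccco4)c4ccccc4n3)CC2)c1Cl` differs from compound 1 by hydrogen in place of fluoro on an aromatic carbon. Among the compounds with values here, no measured step touches this position, so the expected step is a 1.3-fold higher number from compound 1 to compound 3 (0.11 log units; within the scatter), with no direction beyond the scatter. Compound 3 is therefore estimated at 500 nM, with a range of 200 nM to 1500 nM.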

Compound 3, half-maximal inhibitory concentration: 3370 nM
Compound 3: middle estimate off by 6.7-fold (0.83 log units), on the low side, outside the stated range (above it).
By their numbers in this assay, from the lowest: compound 1; then compounds 2 and 3 (each within the scatter of the next).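

In this assay, hydrogen in place of fluoro on an aromatic carbon of the core gives an 8.6-fold higher number from compound 1 to compound 3 (0.94 log units; beyond the scatter), so this position is sensitive to the change and the lower number lies with the fluoro compound. Within the data shown here, this is the only step at this position, so it rests on a single pair with the 2,3-dichlorophenyl group held constant. Nothing available bears on the reason for this step.

Still open, as far as these compounds go, is whether a methoxy group or a nitrile on this carbon would stay near compound 1, and whether the step would be of similar size with the 2,3-dimethylphenyl group of compound 2.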